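Fluoro in place of hydrogen: compound 3 to compound 4

The source may hold more compounds than are shown below. What is called first, only, known or untested is meant among the compounds shown, and "the series" means these compounds.

Measured so far:
- compound 1, `C=C1C[C@]23C[C@@]1(O)CC[C@H]2c1ccc(OS(=O)(=O)c2ccc(C)cc2)c(C)c1[C@@H]3Cn1cc(-c2ccc(Cl)cc2)nn1`: in a functional assay on MCF7 cells (Homo sapiens) for cytotoxicity, read by MTT assay, with a stated time of 4 days (on this read-out higher numbers stand for weaker inhibition and lower numbers for stronger inhibition), compound 1 gives > 20000 nM, a limit of the assay.
- compound 2, `C=C1C[C@]23C[C@@]1(O)CC[C@H]2c1ccc(OS(=O)(=O)c2ccc(C)cc2)c(C)c1[C@@H]3Cn1cc(-c2ccc(Br)cc2)nn1`: in this assay compound 2 gives > 20000 nM, a limit of the assay.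
- compound 3, `C=C1C(=O)[C@]23C[C@@]1(O)CC[C@H]2c1ccc(O)c(C)c1[C@@H]3Cn1cc(-c2ccccc2)nn1`: in this assay compound 3 gives 1740 nM.

Compound 3 is the only one of the three with a number. Compound 1 sits at a limit of the assay. Compound 2 sits at a limit as well. Both share (the limit of > 20000 nM in this assay, at which 2 of the 3 values shown sit), so the step that the two limits leave unreadable from compound 1 to compound 2 is unreadable, and as bromo in place of chloro it does not touch the change at hand. Compound 4, `C=C1C(=O)[C@]23C[C@@]1(O)CC[C@H]2c1ccc(O)c(C)c1[C@@H]3Cn1cc(-c2ccc(F)cc2)nn1`, differs from compound 3 by fluoro in place of hydrogen on an aromatic carbon. Among the compounds with values here, no measured step covers fluoro in place of hydrogen on this ring. The expected step of a 1.0-fold lower number from compound 3 to compound 4 (0.01 log units; within the scatter) is therefore none beyond the scatter. Compound 4 is estimated at 1700 nM, with a range from 600 nM to 5000 nM.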

Compound 4, half-maximal inhibitory concentration: 1700 nM
Estimate against measurement, compound 4: no gap at the digits printed, and the stated range covers the measured number.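

In this assay, within the data shown here, phenyl to 4-fluorophenyl gives a 1.0-fold lower number from compound 3 to compound 4 (0.01 log units; within the scatter), the first readable step at this position. The earlier step on this ring, bromo in place of chloro, cannot be read, as both of its values are limits of the assay. No measurement shown gives a reason for this result. From the compounds shown here alone, it remains open whether an amine, a carboxylic acid or a methoxy group at this position would move the number beyond the scatter. Going by these compounds, whether fluoro behaves the same way on the core of compound 1 is also open.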